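This account rests on a few compounds, and the source may have more. Where it says the series, first, only, none or still open, it means among the compounds named here.

The measured compounds in a functional assay on BT-549 cells (Homo sapiens) for inhibition, read by sulforhodamine B assay, with a stated time of 48 h; a higher number here means a weaker inhibitor of growth, a lower number a stronger inhibitor of growth:

Compound 1 `CC1CCCc2c1nc(N)c(C#N)c2-c1cccn1C` gives 69100 nM.
Compound 2 `Cn1cccc1-c1cc(-c2cccs2)nc(N)c1C#N` gives > 100000 nM.
Compound 3 `COc1ccc(-c2cc(-c3cccn3C)c(C#N)c(N)n2)cc1OC` gives 64600 nM.

Compound 2 stands apart from the other two in this assay: its result, > 100000 nM, is a limit of the assay and not a number, so its growth inhibition is known only to lie beyond the measured range. Compound 1 and compound 3 each give a number, and their values in this assay sit within the usual scatter of one another. Among the measured compounds shown here, none of the three differ from each other in a single place, so no measured step connects them.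

Compound 4 `Cn1cccc1-c1cc(-c2ccccc2)nc(N)c1C#N` has not yet been measured in this assay. It differs from compound 2 in one place: phenyl in place of thiophen-2-yl on an aromatic carbon. Phenyl replaces thiophen-2-yl on an aromatic carbon of the core that compound 2 and compound 4 share.

For the measured compounds named here, with no measured step to guide the size of this change, and with all three measured values in this assay sitting at or close to the limit, compound 4 is expected to remain a weak inhibitor of growth. The step from compound 2 to compound 4 is estimated as an at least 1.1-fold lower number from compound 2 to compound 4 (0.04 log units; that floor lies within the scatter), a change no larger than the scatter of repeated measurements. For compound 4 in this assay the expected value is 90000 nM, with a plausible range from 40000 nM to 200000 nM.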

Compound 4, concentration for 50% growth inhibition: 60200 nM
Estimate against measurement, compound 4: 1.5-fold (0.17 log units) above; the range from low to high includes it.
By their numbers in this assay, from the lowest: compounds 4, 3 and 1 (each within the scatter of the next). At a limit, above all of these: compound 2.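

In this assay compound 2 gives > 100000 nM, which is a limit of the assay and not a number. Phenyl in place of thiophen-2-yl, on the aromatic carbon next to the ring nitrogen and para to a cyano group, gives the first step at this place on the shared core, an at least 1.6-fold lower number from compound 2 to compound 4 (0.22 log units; that floor lies within the scatter), and it shows that this change leads from a limit to a measured number. The size of the change remains unknown, and only a floor can be stated, because one end of the step rests on a limit: the limit of > 100000 nM in this assay, at which 1 of the 4 values shown sits.

The compounds shown leave open whether an aromatic ring is needed at this place at all, since a methyl group, an amine or a carboxylic acid on the same carbon would test that directly in this assay. They also leave open whether another five-membered aromatic ring, such as furan-2-yl, would behave like thiophen-2-yl or like phenyl, and whether any group here could produce a step that clearly lies beyond the scatter.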